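Lipoyl-triazole coumarins: dichloro switch on the longer linker

The source may hold more compounds than are shown below. What is called first, only, known or untested is meant among the compounds shown, and "the series" means these compounds.

The series pairs a lipoyl amide through a triazole to a coumarin bearing a substituted phenyl, with two linker lengths. Compound 1 `O=C(CCCCC1CCSS1)NCc1cn(CCCCOc2ccc3cc(-c4ccc(Br)cc4)c(=O)oc3c2)nn1` and compound 2 `O=C(CCCCC1CCSS1)NCc1cn(CCCCOc2ccc3cc(-c4ccc(Cl)c(Cl)c4)c(=O)oc3c2)nn1` share the shorter linker; compound 3 `O=C(CCCCC1CCSS1)NCc1cn(CCCCCOc2ccc3cc(-c4ccc(Br)cc4)c(=O)oc3c2)nn1` and compound 4 `O=C(CCCCC1CCSS1)NCc1cn(CCCCCOc2ccc3cc(-c4ccc(Cl)c(Cl)c4)c(=O)oc3c2)nn1` share the longer one. How the core of compound 3 differs from the core of compound 1 is not broken down here.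

In a functional assay on PC-12 cells (Rattus norvegicus) for cytotoxicity, read by MTT assay, with stated times of 3 h and 2 h, tested at 5 uM (on this read-out lower numbers stand for a weaker effect and higher numbers for a stronger effect at the one concentration tested), compound 1 gives 40.5%, and compound 2 gives 53.2%. The change between them is 3,4-dichlorophenyl in place of 4-bromophenyl on an aromatic carbon, and it produced a number 12.7 percentage points higher from compound 1 to compound 2 (beyond the scatter). Compound 3 gives 45.7% in this assay; against compound 1 and compound 2 its number sits within the scatter of both, so no order among the three can be read.

The change from compound 3 to compound 4 is 3,4-dichlorophenyl in place of 4-bromophenyl on an aromatic carbon; the place is described in the same words as for the first pair, so this is the same change, now made on the longer linker. Among the measured compounds shown here, only one earlier instance exists, so the expectation rests on it alone: because compound 2 showed a number 12.7 percentage points higher from compound 1 to compound 2 (beyond the scatter) over compound 1, a step of about the same size is expected here, giving a number 12.3 percentage points higher from compound 3 to compound 4 (beyond the scatter). A shift of the step with linker length cannot be excluded from a single precedent. Compound 4 is therefore estimated at 58% in this assay, with a range of 46% to 70%.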

Compound 4, a percentage reported as activity, at one concentration (the size of the read-out at that concentration, not a potency): 54.8%
The estimate for compound 4 lay 3.2 percentage points above the measured number; low and high end bracket the measured number.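

In this assay the exchange of 4-bromophenyl for 3,4-dichlorophenyl gives a number 9.1 percentage points higher from compound 3 to compound 4 (within the scatter) on the longer linker, so this step alone cannot be told apart from repeat-to-repeat variation. Set beside the step on the shorter linker, it shows no measurable difference in the size of the change between the two cores: the same change on two cores in this assay, a number 12.7 percentage points higher (beyond the scatter) from compound 1 to compound 2 and a number 9.1 percentage points higher (within the scatter) from compound 3 to compound 4, 3.6 percentage points apart, within the scatter of two such steps. Among the compounds shown here, this is consistent with the change carrying over between these two cores, but it rests on only two pairs at one concentration, does not establish a real rise on the longer linker, and neither shows nor excludes a smaller step there.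

The compounds shown leave open whether the same step would appear with other groups in place of the 4-bromophenyl, such as an unsubstituted phenyl, a 4-methoxyphenyl or a pyridyl ring. They also leave open how the step would behave with a longer chain than the two linkers here, or with a carboxylic acid or an amine in place of the lipoyl amide.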